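Methoxy for Fluoro on a Benzyl Amide Side Chain

This account rests on a few compounds, and the source may have more. Where it says the series, first, only, none or still open, it means among the compounds named here.

Of the compounds shown here, two share a core and have been tested in a functional assay on A549 cells (Homo sapiens) for cytotoxicity, read by XTT assay, with a stated time of 72 h; on this read-out higher numbers stand for weaker inhibition and lower numbers for stronger inhibition. Compound 1, `COc1ccc(CN(C)C(=O)c2ccc(-c3cc(C4=CC(=O)C=CC4=O)no3)s2)cc1`, reaches only the limit of the assay in this assay, giving > 30000 nM. Compound 2, `COc1ccc(OC)c(-c2cc(-c3ccc(C(=O)N(C)Cc4ccc(F)cc4)s3)on2)c1`, also sits at that limit in this assay, giving > 30000 nM. Within the data shown here, both values shown are therefore limits rather than numbers, as summarised by the limit of > 30000 nM in this assay, at which 2 of the 2 values shown sit; compound 2 stands at the same limit as the only other compound measured, so no ordering between them can be read.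

Compound 3, `COc1ccc(CN(C)C(=O)c2ccc(-c3cc(-c4cc(OC)ccc4OC)no3)s2)cc1`, differs from compound 2 in one place: methoxy in place of fluoro on an aromatic carbon, para to a large group. Among the measured compounds shown here, no step between measured compounds is available to calibrate this change. With compound 2 at > 30000 nM as a limit, the expectation is that compound 3 will again reach the assay limit, and the step of a number no higher from compound 2 to compound 3 (the limit leaves the size open) is expected to be none beyond the scatter. Compound 3 is thus estimated at 30000 nM in this assay, within 10000 nM to 100000 nM.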

Compound 3, half-maximal inhibitory concentration: > 30000 nM
Compound 3: no number, only a limit (the forecaster's own chance of this, stated with the estimate: 80%); the middle value lies on the limit itself.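

Compound 3 also gives only a limit in this assay, as do compound 1 and compound 2, so no step from compound 1 or compound 2 to compound 3 can be read: the limit of > 30000 nM in this assay, at which 3 of the 3 values shown sit.

The compounds shown leave open whether methoxy in place of fluoro changes cytotoxicity at all, and how these three compounds would rank.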